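Silyl ether in place of a phenol on a benzamide

The compounds below may be only part of what the source reports. "The series", "measured", "known", "first", "only" and "open" are said of these compounds alone.

Compound 1 `Nc1cc(O)ccc1NC(=O)c1ccc(CNc2nccc(-c3cccnc3)n2)cc1` gives in an assay on isolated protein for inhibition of protein deacetylase HDAC6 (Homo sapiens), read by fluorescence, with stated times of 3 h and 60 min (a lower number here means a stronger inhibitor, a higher number a weaker inhibitor), only a limit of the assay, > 20000 nM; it sits at the limit of > 20000 nM in this assay, at which 1 of the 3 values shown sits, rather than at a measured number. Among the measured compounds shown here, compound 2 `Nc1ccccc1NC(=O)c1ccc(CNC2=NC[C@@H](c3ccccc3)S2)cc1` has in this assay "not determined" (no result reported), and compound 3 `Nc1ccccc1NC(=O)c1ccc(CNC2=N[C@@H](c3ccc(O)cc3)CS2)cc1` likewise has "not determined" (no result reported), so no step between measured compounds can be drawn. Compound 4 `CC(C)(C)[Si](C)(C)OCc1ccc(NC(=O)c2ccc(CNc3nccc(-c4cccnc4)n3)cc2)c(N)c1` differs from compound 1 by a group of 9 heavy atoms (7 carbon, 1 oxygen, 1 silicon; no ring) in place of one oxygen atom, on an aromatic carbon; the hydroxy leaves from a carbon meta to an amino group and para to a large group. With compound 1 beyond the limit of this assay, no step larger than the scatter is expected from compound 1 to compound 4, a step that the limit leaves unreadable from compound 1 to compound 4. Compound 4 is expected to give about 25000 nM, with a range from 8000 nM to 80000 nM.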

Compound 4, half-maximal inhibitory concentration: > 20000 nM
Compound 4: a limit, no number; the forecaster's own chance of this, stated with the estimate: 70%; the middle value is on the limit's open side.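

Compound 1 and compound 4 both stand at a limit of the assay rather than at a number, so no step can be read between them: the limit of > 20000 nM in this assay, at which 2 of the 4 values shown sit.

Going by these compounds, what replacing the hydroxy with the larger group does in this assay remains open.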